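The source may hold more compounds than are shown below. What is called first, only, known or untested is meant among the compounds shown, and "the series" means these compounds.

Of the compounds shown here, two of a shared core have been tested so far. Compound 1 `O=C(O)CC1COc2cc(OCc3ncc(-c4ccccc4)s3)ccc21` gives 5.26% in a functional assay on CHO cells for agonist activity at Free fatty acid receptor 1 (Homo sapiens), read by FLIPR and calcium flux, tested at 100 nM; on this read-out higher numbers stand for a stronger effect at the one concentration tested and lower numbers for a weaker effect. Compound 2 `Cc1nc(-c2cc3ccccc3o2)sc1COc1ccc2c(c1)OCC2CC(=O)O` gives 14.8% in this assay, the higher of the two numbers, though the gap to compound 1 lies within the usual scatter, so the two cannot be told apart with confidence. Both sit at the weak end of the scale.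

Compound 3 `Cc1nc(-c2ccccc2F)sc1COc1ccc2c(c1)OCC2CC(=O)O` has not been measured yet. It differs from compound 2 in one place: 2-fluorophenyl in place of 1-benzofuran-2-yl on an aromatic carbon. The group that leaves holds a five-membered aromatic ring fused to a six-membered one and carries one hydrogen-bond acceptor; the group that enters is a single six-membered ring of carbon only with a fluorine on it and no acceptor.

Among the measured compounds shown here, no measured pair shows what such a change does here. Given that compound 1, with a plain six-membered ring of carbon only, gives 5.26%, the step from compound 2 to compound 3 is expected to be small, if anything downward, and not beyond the scatter: a number 6.8 percentage points lower from compound 2 to compound 3 (within the scatter). For compound 3 the expected value in this assay is 8%, with a range from 0% to 25%.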

Compound 3, a percentage reported as activity, at one concentration (the size of the read-out at that concentration, not a potency): 25.8%
For compound 3 the middle estimate is 17.8 percentage points below the measured one; the measured number lies above the stated range.
By their numbers in this assay, from the lowest: compounds 1 and 2 (each within the scatter of the next); then compound 3.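

Among the compounds shown here, this is the first measured change at the aromatic carbon next to the ring nitrogen and next to the ring sulfur of the five-membered aromatic ring, and in this assay it gives a number 11 percentage points higher from compound 2 to compound 3 (beyond the scatter). The fused 1-benzofuran-2-yl group is therefore not required here for the effect seen at the one concentration tested, since a single six-membered ring of carbon only, as 2-fluorophenyl, gives the higher number. Nothing available explains why the number rises.

The compounds shown leave open whether the fluorine itself matters, which a plain phenyl in place of 2-fluorophenyl in compound 3 would test, and whether a methoxy group or a nitrile on that ring would change the number. With one concentration only, the numbers also give no potency.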